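The source may hold more compounds than are shown below. What is called first, only, known or untested is meant among the compounds shown, and "the series" means these compounds.

Within the data shown here, in an ADME assay on microsomes from liver (Mus musculus) for metabolic stability, with a stated time of 10 min (a higher number here means that more of the compound is left, a lower number that less of the compound is left), three compounds on the shared core have numbers so far. Compound 1 (`Cc1c(Cl)cccc1Oc1cccn2c(C34CCC(CC3)C4)nnc12`) gives 57%, compound 2 (`Cc1c(Cl)cccc1Oc1cccn2c([C@]34CCC(C[C@H]3O)C4(C)C)nnc12`) gives 21%, and compound 3 (`Cc1c(Cl)cccc1Oc1cccn2c(C3CCOCC3)nnc12`) gives 100%, the highest of the three and beyond the scatter from both others.

The next structure is compound 4 (`Cc1c(Cl)cccc1Oc1cccn2c(C34CCC(F)(CC3)CC4)nnc12`), which carries a group of 9 heavy atoms (8 carbon, 1 fluorine; 2 six-membered non-aromatic rings of carbon only) in place of a group of 6 heavy atoms (5 carbon, 1 oxygen; one six-membered non-aromatic ring with 1 hetero atom), on an aromatic carbon. Among the measured compounds shown here, one measured step bears on this change: a number 43 percentage points higher from compound 1 to compound 3 (beyond the scatter). That large step also exchanges oxan-4-yl and a group with rings of carbon only, but in the opposite direction. For the measured compounds named here, no measured step links compound 2 to the others, and no fluorine-bearing group has been measured yet, so the comparison rests on one pair. A large fall in this assay, beyond the scatter and of similar size to that step, is therefore expected. The expected change is a number 45 percentage points lower from compound 3 to compound 4 (beyond the scatter). Compound 4 is estimated at 55%, with an expected range from 33% to 78%.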

Compound 4, percent of the compound remaining: 62%
Compound 4: the middle estimate sits 7 percentage points below what was measured; measured number inside the range.
By their numbers in this assay, from the lowest: compound 2; then compounds 1 and 4 (each within the scatter of the next); then compound 3.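

With a number 38 percentage points lower from compound 3 to compound 4 (beyond the scatter) in this assay, the oxan-4-yl group of compound 3 now stands apart from a second group with rings of carbon only, at the same aromatic carbon of the shared core. With a number 5 percentage points higher from compound 1 to compound 4 (within the scatter) the change of ring size and the added fluorine leave no readable difference between these two groups, so the two six-membered rings of compound 4 and the two five-membered rings of compound 1 cannot be told apart in this read-out. No measurement shown here accounts for either step.

Still open, going by these compounds, is whether the step follows the ring oxygen or the size of the group, which a plain cyclohexyl or a piperidin-4-yl ring at this position would help to separate. On these data alone, the part played by the fluorine is also open, as the group of compound 4 appears here only with that atom and not with hydrogen or a hydroxyl in its place.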